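The source may report more compounds than this note shows. Statements on the series, on what has been measured and on what is new or still open speak of the compounds shown alone.

Compound 1 `Cc1nc2c(OCc3ccccc3)cccn2c1C#N` gives 4% in a functional assay on the whole organism (stomach) for inhibition, with Canis familiaris (Canis lupus familiaris) as the target, at a dose of 5 mg/kg by the intravenous route; on this read-out higher numbers stand for a stronger effect at the one dose given and lower numbers for a weaker effect; compound 2 `CSCc1c(C)nc2c(OCc3ccccc3)cccn12` gives 8%.

Compound 2 shows a number that, together with that of compound 1, sits within the scatter of repeated measurements: the step of a number 4 percentage points higher from compound 1 to compound 2 (within the scatter) does not exceed it. Compound 3 `COC(=O)Cc1c(C)nc2c(OCc3ccccc3)cccn12` differs from compound 2 by methoxycarbonyl in place of methylsulfanyl on a saturated chain carbon bound to an aromatic carbon. Among the compounds with values here, the only measured step, exchanging one group for another at the same saturated chain carbon bound to an aromatic carbon, was a number 4 percentage points higher from compound 1 to compound 2 (within the scatter), so no shift beyond the scatter is expected here either, and the step of no change at the digits printed from compound 2 to compound 3 (within the scatter) is estimated to be small. Compound 3 is therefore expected to give 8%, between 0% and 22%.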

Compound 3, a percentage reported as inhibition, in the whole organism at one dose (the size of the read-out at that dose, not a potency): 16%
Beside the measured number, compound 3's estimate is 8 percentage points below it; the range from low to high includes it.
By their numbers in this assay, from the lowest: compounds 1, 2 and 3 (each within the scatter of the next, the first and the last beyond it).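

In this assay, methoxycarbonyl in place of methylsulfanyl on the saturated chain carbon gives a number 8 percentage points higher from compound 2 to compound 3 (within the scatter), so this exchange does not separate the two groups. Within the data shown here, with (methoxycarbonyl)methyl in place of cyano on an aromatic carbon, the step of a number 12 percentage points higher from compound 1 to compound 3 (beyond the scatter) is the first in this set to pass the scatter, though only modestly. No available evidence bears on this result. The compounds shown leave open whether a carboxylic acid, an amine or a longer chain at this place would give a larger number.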